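A few compounds are considered here, and "the series" means these few. Any claim that something is new, unique, unknown or untested is made for them only; others in the source may bear on it.

Three compounds have been measured in an ADME assay for permeability, using PAMPA; a lower number here means that the compound crosses the layer more slowly, a higher number that the compound crosses the layer faster:

Compound 1 `CCCC[C@H](NC(=O)[C@H](CCCCN)NC(=O)[C@H](CCCNC(=N)N)NC(=O)c1ccc(/C=C2\SC(=O)N(c3ccc(C)cc3)C2=O)cc1)C(N)=O` gives 0.66 10^-6 cm/s.
Compound 2 `CCCC[C@H](NC(=O)[C@H](CCCCN)NC(=O)[C@H](CCCNC(=N)N)NC(=O)c1ccc(/C=C2\SC(=S)N(Cc3ccc(OC)cc3)C2=O)cc1)C(N)=O` gives 0.6 10^-6 cm/s.
Compound 3 `CCCC[C@H](NC(=O)[C@H](CCCCN)NC(=O)[C@H](CCCNC(=N)N)NC(=O)c1ccc(/C=C2\SC(=S)N(c3ccc(Cl)cc3)C2=O)cc1)C(N)=O` gives 1.02 10^-6 cm/s.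

Compound 1 stands second highest of these three numbers. Its nearest neighbour is compound 2, and the gap between them is within the scatter; its furthest neighbour is compound 3, and that gap is also within the scatter. The three numbers therefore cannot be told apart.

Compound 4 `CCCC[C@H](NC(=O)[C@H](CCCCN)NC(=O)[C@H](CCCNC(=N)N)NC(=O)c1ccc(/C=C2\SC(=O)N(CCCC)C2=O)cc1)C(N)=O` differs from compound 1 in one place: butyl in place of 4-methylphenyl on an amide-type nitrogen in a ring.

Going by the values given here, only one measured step touches the same position: a 1.7-fold higher number from compound 2 to compound 3 (0.23 log units; within the scatter). That step, 4-chlorophenyl in place of 4-methoxybenzyl on an amide-type nitrogen in a ring, stays within the scatter. Among the compounds with values here, no measured step puts a plain chain such as butyl on that nitrogen, so the present change is not directly covered. Since every group tried there so far has left the number where it was, no step beyond the scatter is expected in this assay either. The value of compound 4 is estimated at 0.7 10^-6 cm/s, with a range from 0.35 10^-6 cm/s to 1.4 10^-6 cm/s. This estimate corresponds to an expected 1.1-fold higher number from compound 1 to compound 4 (0.03 log units; within the scatter).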

Compound 4, apparent permeability: 1.18 10^-6 cm/s
Estimate against measurement, compound 4: 1.7-fold (0.23 log units) below, and the stated range covers the measured number.
By their numbers in this assay, from the lowest: compounds 2, 1, 3 and 4 (each within the scatter of the next).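

Until now, every group on this amide-type nitrogen carried a six-membered aromatic ring, so it was unknown whether the number in this assay would hold without one. Replacing 4-methylphenyl with butyl removes that ring and leaves a smaller group, with 4 heavy atoms in place of 7, yet the result is only (a 1.8-fold higher number from compound 1 to compound 4 (0.25 log units; within the scatter)), so in this pair neither the loss of the ring nor the smaller size moves the number beyond what repeated measurements would show. Nothing in the available data explains the outcome at the level of mechanism, and it offers no independent measurement to say why this nitrogen shows so little response.

Butyl and 4-methylphenyl both have no hydrogen-bond donors or acceptors and no net charge, so it remains open whether an amine, a carboxylic acid or a hydroxyl group at the end of a chain on this nitrogen, or a chain much longer than butyl, would also stay within the scatter. On these data alone, it is also open whether butyl would behave the same way on the core of compound 3, which differs from the core of compound 1.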